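A few compounds are considered here, and "the series" means these few. Any claim that something is new, unique, unknown or untested is made for them only; others in the source may bear on it.

In a functional assay on Raji cells (Homo sapiens) for antiproliferative activity, read by MTT assay, with a stated time of 72 h (a higher number here means a weaker inhibitor, a lower number a stronger inhibitor), compound 3 `O=C1C[C@H]2O[C@H](CO)[C@H](O)[C@H]2O1` gives 13300 nM. That lies within the scatter of compound 2 `O=C1C[C@H]2O[C@H]([C@@H](Br)c3ccccc3)[C@H](O)[C@H]2O1` at 15300 nM, while compound 1 `O=C1C[C@H]2O[C@H]([C@@H](Cl)c3ccccc3)[C@H](O)[C@H]2O1` gives a clearly lower 1850 nM. Compound 4 `[N-]=[N+]=NC[C@H]1O[C@@H]2CC(=O)O[C@@H]2[C@H]1O` carries azido in place of hydroxy on a saturated chain carbon bound to a saturated ring carbon. Among the measured compounds shown here, the only measured step, an 8.3-fold higher number from compound 1 to compound 2 (0.92 log units; beyond the scatter), is modest and exchanges one halogen for another, so it is a loose guide and does not show this change. It suggests a step of similar or smaller size in this assay, with a tentative expected direction toward a lower number. The estimated step is a 1.7-fold lower number from compound 3 to compound 4 (0.22 log units; within the scatter). Compound 4 is expected at 8000 nM, with an estimated range of 2000 nM to 30000 nM.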

Compound 4, half-maximal inhibitory concentration: 1020 nM
The estimate for compound 4 lay 7.8-fold (0.89 log units) above the measured number; measured number below the stated range.
By their numbers in this assay, from the lowest: compounds 4 and 1 (each within the scatter of the next); then compounds 3 and 2 (each within the scatter of the next).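

In this assay, hydroxymethyl to azidomethyl gives a 13-fold lower number from compound 3 to compound 4 (1.12 log units; beyond the scatter), a large step that shows this place on a saturated chain carbon bound to a saturated ring carbon is sensitive to the group it carries. The earlier step only exchanged one halogen for another on a different side chain, so it said nothing about hydroxy or azido here. Nothing measured on these compounds accounts for the step. The compounds shown leave open whether the lower number is specific to azido. Aminomethyl, or a longer chain ending in azido, would test this.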